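From Isopropyl to Pyridin-2-yl on the Ring Amine

The compounds below may be only part of what the source reports. "The series", "measured", "known", "first", "only" and "open" are said of these compounds alone.

Compound 1 `Cc1cccc2sc(NC(=O)CCN3CCN(C(C)C)CC3)nc12` was examined in an assay on membranes from liver for displacement of a labelled ligand from Sigma intracellular receptor 2 (Rattus norvegicus), read by scintillation counting, with a stated time of 120 min (on this read-out higher numbers stand for weaker inhibition and lower numbers for stronger inhibition), where compound 1 gives 1800 nM. Compound 2 `CCCCN1CCN(CCC(=O)Nc2nc3c(C)cccc3s2)CC1` carries butyl in place of isopropyl on the amine nitrogen in the ring, and in this assay compound 2 gives 1200 nM. Compound 1 and compound 2 cannot be told apart, since the step of a 1.5-fold lower number from compound 1 to compound 2 (0.18 log units; within the scatter) lies within the scatter. Compound 3 `Cc1cccc2sc(NC(=O)CCN3CCN(CCN(C)C)CC3)nc12` bears 2-(dimethylamino)ethyl in place of isopropyl on that nitrogen. In this assay compound 3 reaches only a limit, > 1000 nM. The step that the limit leaves unreadable from compound 1 to compound 3 thus cannot be sized because of the limit of > 1000 nM in this assay, at which 1 of the 3 values shown sits.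

Compound 4 `Cc1cccc2sc(NC(=O)CCN3CCN(c4ccccn4)CC3)nc12` differs from compound 1 in one place: pyridin-2-yl in place of isopropyl on an amine nitrogen in a ring. Among the compounds with values here, the one readable step at this nitrogen, a 1.5-fold lower number from compound 1 to compound 2 (0.18 log units; within the scatter), trades one alkyl group for another and stays within the scatter, while no aromatic group on this nitrogen has yet been measured and the step that the limit leaves unreadable from compound 1 to compound 3 gives no size. The expectation for compound 4 is therefore a number close to that of compound 1, with no shift beyond the scatter but with wide uncertainty. For compound 4 in this assay the estimate is 2000 nM, between 600 nM and 7000 nM. That estimate means an expected step of a 1.1-fold higher number from compound 1 to compound 4 (0.05 log units; within the scatter).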

Compound 4, inhibition constant: > 1000 nM
Compound 4: only a limit was reported; the forecaster's own chance of this, stated with the estimate: 40%; the middle value does not contradict the limit.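

In this assay compound 4 reaches only a limit, > 1000 nM. Its steps from compound 1, compound 2 and compound 3 cannot be read, so this result yields no new step: the limit of > 1000 nM in this assay, at which 2 of the 4 values shown sit.

The compounds shown leave open whether pyridin-2-yl in place of isopropyl or butyl on the amine nitrogen in the ring shifts the number in this assay at all, and in which direction.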